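A few compounds are considered here, and "the series" means these few. Any claim that something is new, unique, unknown or untested is made for them only; others in the source may bear on it.

Measured so far:

Compound 1, `Cc1ccc2nc(N(C)C)nc(NCc3ccc(C(=O)NC4CCN(Cc5ccc(F)cc5)CC4)cc3)c2c1`, in a functional assay on HCT-116 cells (Homo sapiens) for inhibition, read by crystal violet staining and colony formation, with a stated time of 9 days (a higher number here means a weaker inhibitor, a lower number a stronger inhibitor), gives 313 nM.
Compound 2, `CCCNc1nc(NCc2ccc(C(=O)Nc3ccc(F)cc3)cc2)c2ccccc2n1`, in this assay gives 684 nM.

Of these two numbers, compound 2 stands at the higher one, so it is the weaker inhibitor of the pair. The gap between compound 2 and compound 1 is larger than the usual scatter of repeated measurements. The two compounds share a core but differ in several places at once, so nothing about any single change can be read from that gap.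

Compound 3, `CCCCNc1nc(NCc2ccc(C(=O)Nc3ccc(F)cc3)cc2)c2ccccc2n1`, is compound 2 with one small change: methyl in place of hydrogen on a saturated chain carbon, three bonds along the chain from a nitrogen on an aromatic ring. Within the data shown here, no measured pair here shows what such a lengthening of the chain does in this assay, so there is no direct guide. A change this small usually moves the read-out little, and the expected step of a 1.2-fold lower number from compound 2 to compound 3 (0.09 log units; within the scatter) is therefore within the scatter. Compound 3 is expected to give 560 nM, with a plausible range from 250 nM to 1300 nM.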

Compound 3, half-maximal inhibitory concentration: 381 nM
Estimate against measurement, compound 3: 1.5-fold (0.17 log units) above; low and high end bracket the measured number.
By their numbers in this assay, from the lowest: compounds 1, 3 and 2 (each within the scatter of the next, the first and the last beyond it).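

Lengthening propyl to butyl gives a 1.8-fold lower number from compound 2 to compound 3 (0.25 log units; within the scatter), the first step here that isolates a single change, and in this assay it leaves compound 2 and compound 3 indistinguishable. So a methyl in place of hydrogen on this saturated chain carbon, three bonds along the chain from a nitrogen on an aromatic ring, gives no measurable gain or loss, and this one step shows no sensitivity to chain length at this point. Nothing else measured on these compounds bears on this result.

On these data alone, it remains open whether a longer chain such as pentyl, a cyclohexyl group or a chain ending in a hydroxyl group would also leave the number unchanged. As far as these compounds go, it is also open whether lengthening this chain would read the same alongside the amide part of compound 1.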